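This account rests on a few compounds, and the source may have more. Where it says the series, first, only, none or still open, it means among the compounds named here.

Of the compounds shown here, three built on one shared core have been measured in a functional assay on HepG2 cells (Homo sapiens) for cytotoxicity, read by MTT assay, with a stated time of 72 h; on this read-out lower numbers stand for stronger inhibition and higher numbers for weaker inhibition. Compound 1 `CCN(CC)CCCOc1c(OCc2ccccc2)cc(O)c2c(=O)cc(-c3ccccc3)oc12` gives 3010 nM in this assay. Compound 2 `O=c1cc(-c2ccccc2)oc2c(OCCCN3CCCC3)c(OCc3ccccc3)cc(O)c12` gives 2660 nM in this assay, and compound 3 `CN(C)CCCCOc1c(OCc2ccccc2)cc(O)c2c(=O)cc(-c3ccccc3)oc12` gives 2090 nM in this assay. Compound 3 thus carries the lowest of the three numbers, yet the step of a 1.3-fold lower number from compound 2 to compound 3 (0.10 log units; within the scatter) and the step of a 1.4-fold lower number from compound 1 to compound 3 (0.16 log units; within the scatter) both lie within the scatter, so no order among the three compounds can be claimed from these values.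

Compound 4 `O=c1cc(-c2ccccc2)oc2c(OCCCCN3CCCC3)c(OCc3ccccc3)cc(O)c12` has not yet been measured in this assay. It differs from compound 3 by pyrrolidin-1-yl in place of dimethylamino on a saturated chain carbon, four bonds along the chain from an oxygen on an aromatic ring. Among the measured compounds shown here, two measured steps bear on this change. The step of a 1.1-fold lower number from compound 1 to compound 2 (0.05 log units; within the scatter) exchanged an acyclic amine for the same five-membered ring and stayed within the scatter. The step of a 1.3-fold lower number from compound 2 to compound 3 (0.10 log units; within the scatter) ran in the opposite direction, from the ring to an acyclic amine on a differently named chain, and also stayed within the scatter. On this basis compound 4 is expected to show no step beyond the scatter in this assay, the expected step being a 1.1-fold higher number from compound 3 to compound 4 (0.04 log units; within the scatter). The estimate for compound 4 in this assay is 2300 nM, with a range from 1200 nM to 4500 nM.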

Compound 4, half-maximal inhibitory concentration: 4660 nM
Beside the measured number, compound 4's estimate is 2.0-fold (0.31 log units) below it; the whole stated range lies below it.
By their numbers in this assay, from the lowest: compounds 3, 2, 1 and 4 (each within the scatter of the next, the first and the last beyond it).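

Among the compounds shown here, the change of dimethylamino to pyrrolidin-1-yl, four bonds along the chain from an oxygen on an aromatic ring, gives the first step in this assay that passes the scatter: a 2.2-fold higher number from compound 3 to compound 4 (0.35 log units; beyond the scatter). This separation holds only for that one pair, since the other two new steps, a 1.8-fold higher number from compound 2 to compound 4 (0.24 log units; within the scatter) and a 1.5-fold higher number from compound 1 to compound 4 (0.19 log units; within the scatter), both stay within the scatter, and the earlier exchange of diethylamino for pyrrolidin-1-yl, a 1.1-fold lower number from compound 1 to compound 2 (0.05 log units; within the scatter), does as well. The amine on this chain can therefore shift the number modestly, but only compound 3 and compound 4 show it, and nothing given here accounts for the step.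

The compounds shown leave open whether the step from dimethylamino to pyrrolidin-1-yl would recur on the shorter chain, as the 3-(dimethylamino)propyl and 3-(pyrrolidin-1-yl)propyl pair is one reading of the same change on a single chain only. They also leave open how diethylamino on the chain of compound 4, a six-membered piperidine or morpholine ring at the chain end, or a longer chain carrying either amine would stand in this assay.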